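This account rests on a few compounds, and the source may have more. Where it says the series, first, only, none or still open, it means among the compounds named here.

Three compounds share one core and differ only in the group attached to it. Compound 1 `COc1ccccc1Oc1ccc2c(NCCCNCc3ccco3)ccnc2c1` gives 14500 nM in a physicochemical assay for solubility, with a stated time of 18 h, at pH 7.4; on this read-out lower numbers stand for lower solubility and higher numbers for higher solubility. Compound 2 `Fc1ccc(-c2ccc3c(NCCCNCc4ccco4)ccnc3c2)cc1` gives 32000 nM in the same assay, and compound 3 `FC(F)(F)c1ccc(-c2ccc3c(NCCCNCc4ccco4)ccnc3c2)cc1` gives 32000 nM. The two changes leading away from compound 1 each raised the number: a 2.2-fold higher number from compound 1 to compound 2 (0.34 log units; beyond the scatter), and a 2.2-fold higher number from compound 1 to compound 3 (0.34 log units; beyond the scatter). Between the two six-membered aryl groups the change was no change at the digits printed from compound 2 to compound 3 (within the scatter). Compound 3 therefore stands level with compound 2 at the top of these three numbers, with compound 1 the furthest away.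

Compound 4 `c1coc(CNCCCNc2ccnc3cc(-c4cccc5ccccc45)ccc23)c1` carries the change (naphthalen-1-yl in place of 4-(trifluoromethyl)phenyl on an aromatic carbon). For the measured compounds named here, the one measured step in which a single aryl group was exchanged for another, from compound 2 to compound 3, showed no change. The entering group is larger than the leaving one and adds a second aromatic ring, so a small drop in this assay is expected, likely at or near the edge of the scatter. For compound 4 the expected change is a 2.0-fold lower number from compound 3 to compound 4 (0.30 log units; within the scatter), giving an estimated value of 16000 nM with a range from 6000 nM to 40000 nM.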

Compound 4, solubility: 32000 nM
Beside the measured number, compound 4's estimate is 2.0-fold (0.30 log units) below it; the measured number falls inside the stated range.
By their numbers in this assay, from the lowest: compound 1; then compounds 2, 3 and 4 (each within the scatter of the next).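

In this assay, the two-ring naphthalen-1-yl group behaves like the single-ring groups at this position: putting it in place of 4-(trifluoromethyl)phenyl gives no change at the digits printed from compound 3 to compound 4 (within the scatter), and putting it in place of 4-fluorophenyl gives no change at the digits printed from compound 2 to compound 4 (within the scatter). In place of 2-methoxyphenoxy it gives a 2.2-fold higher number from compound 1 to compound 4 (0.34 log units; beyond the scatter), so the step seen earlier from compound 1 to each of compound 2 and compound 3 also appears with a group carrying a second aromatic ring. Nothing offered here accounts for this result.

The groups shown at this position are all aromatic, so it remains open whether a group carrying an amine or a carboxylic acid would shift the number. As far as these compounds go, it is also open whether a longer chain elsewhere on the shared core would matter more than the aryl group does.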